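Working notes on compounds 1 to 4

This account rests on a few compounds, and the source may have more. Where it says the series, first, only, none or still open, it means among the compounds named here.

Measured so far:
compound 1 `C[C@H]1C[C@@H]2OC(=O)[C@H](C)[C@H]2C=CC1=O`: > 10000 nM
compound 2 `C[C@H]1C[C@@H]2OC(=O)[C@H](C)[C@H]2CC=C1C=O`: > 10000 nM
compound 3 `C=C1C(=O)O[C@H]2CC[C@H](C)C(/C=C/C(C)=O)=C[C@H]12`: 1600 nM

In a functional assay on BV-2 cells (Mus musculus, strain C57BL6/J) for inhibition, read by Griess assay, with a stated time of 24 h (a lower number here means a stronger inhibitor, a higher number a weaker inhibitor), compound 1 reports only a limit, > 10000 nM. Compound 2 likewise reports only a limit in this assay, > 10000 nM, so its standing is known only as a limit and not as a number. Among the measured compounds shown here, compound 3 gives 1600 nM in this assay, the one numerical value in the set. For the measured compounds named here, two of the three values sit at the limit of > 10000 nM in this assay, at which 2 of the 3 values shown sit, and no pair of measured compounds differs in a single place, so no measured step is available to calibrate the change that follows.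

Compound 4 `CC(=O)CCC1=CC[C@H]2[C@H](C[C@@H]1C)OC(=O)[C@@H]2C` differs from compound 2 by 2-acetylethyl in place of formyl on a double-bonded ring carbon. Nothing measured here isolates the effect of that exchange. Compound 2 starts from a limit, so the step from compound 2 to compound 4 can only be stated relative to that limit; the expectation is that compound 4 stays in the same region, with no step beyond the scatter, as a step that the limit leaves unreadable from compound 2 to compound 4. The estimate for compound 4 in this assay is 20000 nM, with a range from 6000 nM to 60000 nM, and it is expected that the assay may again report only a limit for compound 4.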

Compound 4, half-maximal inhibitory concentration: > 10000 nM
Compound 4 ended at the assay's limit; the forecaster's own chance of this, stated with the estimate: 70%; the middle value lies beyond the limit too.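

In this assay compound 4 gives > 10000 nM, a limit and not a number. Among the compounds shown here, compound 2 also stands only at a limit, so no step between compound 2 and compound 4 can be read. The compounds shown leave open whether 2-acetylethyl in place of formyl on a double-bonded ring carbon changes inhibition at all in this assay.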